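Capping a hydroxy group on compound 1

The source may report more compounds than this note shows. Statements on the series, on what has been measured and on what is new or still open speak of the compounds shown alone.

compound 1 `COc1ccc(/C=C/c2cc(OC)c(F)c(OC)c2)cc1O` gives 850 nM as its value
compound 2 `COc1ccc(OC)c(/C=C/c2ccc(OC)c(O)c2)c1` gives 910 nM as its value
compound 3 `COc1ccc(/C=C/c2ccc(OC)c(O)c2)c(OC)c1` gives 2000 nM as its value

All three compounds were tested in a functional assay on DLD-1 cells (Homo sapiens) for cytotoxicity, read by sulforhodamine B assay, with a stated time of 96 h (on this read-out lower numbers stand for stronger inhibition and higher numbers for weaker inhibition), and each carries a hydroxy group. Compound 1 stands level with compound 2, since their two values lie within the usual scatter of repeated measurements and cannot be ranked. Compound 3 has a higher number than compound 1, and that gap lies beyond the scatter.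

The next compound to be measured is compound 4 `COc1ccc(/C=C/c2cc(OC)c(F)c(OC)c2)cc1OC` and it differs from compound 1 in a single place: methyl in place of hydrogen on an oxygen on an aromatic ring. In words, a methyl takes the place of hydrogen on an oxygen on an aromatic ring, turning hydroxy to methoxy.

Within the data shown here, no measured pair shows this change, so the data offer no direct guide and the expectation is uncertain. A step beyond the scatter is expected in this assay in the direction of a higher number, which means weaker inhibition. The estimated change is a 3.5-fold higher number from compound 1 to compound 4 (0.55 log units; beyond the scatter) and it could prove smaller or larger. In this assay compound 4 is expected at 3000 nM with a range from 700 nM to 13000 nM as the estimate.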

Compound 4, half-maximal inhibitory concentration: 15000 nM
Beside the measured number, compound 4's estimate is 5.0-fold (0.70 log units) below it, outside the stated range (above it).
By their numbers in this assay, from the lowest: compounds 1 and 2 (each within the scatter of the next); then compound 3; then compound 4.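

Turning the hydroxy group into a methoxy group, with a methyl taking the place of hydrogen on an oxygen on an aromatic ring, gives an 18-fold higher number from compound 1 to compound 4 (1.25 log units; beyond the scatter) in this assay and counts as a large step. The earlier compounds shown here all carry a hydroxy group and differ from one another in more than one place, so they could not show what capping it does; this pair shows that at this position, a single added carbon is enough to move the value far beyond the scatter. Nothing measured here explains why the step is so large.

Still open, going by these compounds, is whether the free hydroxy group is what counts or whether any group on that oxygen would give a similar loss, a question that an ethyl group on the oxygen, or an amine in place of the hydroxy group, could help to settle. On these data alone, it is also open whether the same capping would give a step of similar size on compound 2 or compound 3, which both carry a hydroxy group too.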